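Changing the ring on the oxygen

This account rests on a few compounds, and the source may have more. Where it says the series, first, only, none or still open, it means among the compounds named here.

In an ADME assay on the whole organism (Rattus norvegicus) for pharmacokinetics, at a dose of 3 mg/kg by the oral route (on this read-out lower numbers stand for lower oral bioavailability and higher numbers for higher oral bioavailability), compound 1 `C[C@@H](Cn1c(=O)[nH]/c(=N\c2ccc(Oc3ccccn3)cc2)n(Cc2ccc(Cl)cc2)c1=O)C(=O)O` gives 76.8%. Among the measured compounds shown here, compound 2 `C[C@@H](Cn1c(=O)[nH]/c(=N\c2ccc(Oc3ccnc(F)c3)cc2)n(Cc2ccc(Cl)cc2)c1=O)C(=O)O` gives 46.9%, the lower of the two numbers so far. Compound 3 `C[C@@H](Cn1c(=O)[nH]/c(=N\c2ccc(Oc3ccsn3)cc2)n(Cc2ccc(Cl)cc2)c1=O)C(=O)O` is the next to be read, and its difference from compound 2 is 1,2-thiazol-3-yl in place of 2-fluoropyridin-4-yl on an oxygen on an aromatic ring. For the measured compounds named here, only one measured step bears on this change, the one at the same place, a number 29.9 percentage points lower from compound 1 to compound 2 (beyond the scatter). Going by the values given here, it lies beyond the scatter and shows that a swap of this group can matter, but no measured compound carries 1,2-thiazol-3-yl, so the direction is poorly defined. The expected step is a number 8.1 percentage points higher from compound 2 to compound 3 (within the scatter), an estimate that stays within the scatter. For compound 3 the expected value is 55%, with an estimated range of 30% to 80%.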

Compound 3, oral bioavailability: 60%
The estimate for compound 3 lay 5 percentage points below the measured number, and the stated range covers the measured number.
By their numbers in this assay, from the lowest: compound 2; then compound 3; then compound 1.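

In this assay, the position on the oxygen now gives three separate levels rather than a single drop: a number 13.1 percentage points higher from compound 2 to compound 3 (beyond the scatter) and a number 16.8 percentage points lower from compound 1 to compound 3 (beyond the scatter), both beyond the scatter. The five-membered 1,2-thiazol-3-yl ring of compound 3 therefore falls between the two six-membered rings of compound 2 and compound 1, so ring size alone does not order these three compounds. Nothing available here gives a measured basis for this order.

Compound 1 and compound 2 differ in both the fluorine and the ring attachment, so the contribution of each remains unresolved, and pyridin-4-yl would be needed to separate them. On these data alone, whether a plain phenyl ring at this oxygen would stay near compound 1 or fall nearer compound 2 also remains open.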